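From a Nitrooxy Chain to a Ring on Compound 1

The source may hold more compounds than are shown below. What is called first, only, known or untested is meant among the compounds shown, and "the series" means these compounds.

In a functional assay (aorta) with Rattus norvegicus as the target, in the presence of a further agent that is not named here (a lower number here means that less compound is needed, a higher number that more compound is needed for the effect), compound 1 (`COC(=O)C1=C(C)N=C(C)/C(=C(/O)OC)C1c1ccccc1OCCO[N+](=O)[O-]`) gives 56 nM and holds the lower of the two numbers available. Compound 2 (`COC(=O)C1=C(C)N=C(C)/C(=C(/O)OC)C1c1cccc(OCc2nonc2C(N)=O)c1`) gives 3500 nM in this assay and lies beyond the scatter from compound 1. Compound 3 (`COC(=O)C1=C(C)N=C(C)/C(=C(/O)OC)C1c1ccccc1OCc1c(C(N)=O)no[n+]1[O-]`) has not yet been measured, and it carries a group of 9 heavy atoms (3 carbon, 3 nitrogen, 3 oxygen; one five-membered aromatic ring with 3 hetero atoms) in place of a group of 5 heavy atoms (1 carbon, 1 nitrogen, 3 oxygen; no ring), on a saturated chain carbon bound to an oxygen on an aromatic ring relative to compound 1. Going by the values given here, no step between measured compounds that differ in one place is available to guide the expectation. Compound 2 also carries a five-membered aromatic ring and stands at 3500 nM in this comparison, but it differs from compound 1 in more than one place, so it offers only a loose guide. The estimated step is a 3.6-fold higher number from compound 1 to compound 3 (0.55 log units; beyond the scatter) towards a higher number and beyond the scatter. The estimate for compound 3 is 200 nM with an expected range from 50 nM to 1000 nM in this assay once it is measured.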

Compound 3, half-maximal effective concentration: 560 nM
Estimate against measurement, compound 3: 2.8-fold (0.45 log units) below; low and high end bracket the measured number.
By their numbers in this assay, from the lowest: compound 1; then compound 3; then compound 2.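

Going by these compounds alone, replacing the (nitrooxy)methyl group on a saturated chain carbon bound to an oxygen on an aromatic ring gives a 10-fold higher number from compound 1 to compound 3 (1.00 log units; beyond the scatter) in this assay and provides the first step that can be read at this place. It shows that this place accepts the larger group with its five-membered aromatic ring and still gives a measurable effect, though more compound is needed than for compound 1. Nothing measured here accounts for the size of this step.

A single step cannot show whether it follows from the ring, from its amide, or from the loss of the nitrooxy group. The compounds shown also leave open how a longer chain ending in the nitrooxy group, or a carboxylic acid in place of the amide, would read in this assay on the same core.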